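Swapping a hydroxyphenyl group on a pyridine-linked scaffold

This account rests on a few compounds, and the source may have more. Where it says the series, first, only, none or still open, it means among the compounds named here.

Measured compounds in an assay on isolated protein for inhibition of DNA topoisomerase 1 (Homo sapiens), with a stated time of 30 min, tested at 100 uM; a higher number here means a stronger effect of the compound at the concentration tested, a lower number a weaker effect:
compound 1 `Oc1cccc(-c2cc(-c3ccsc3)cc(-c3ccccc3O)n2)c1`, 10.2%
compound 2 `Oc1cccc(-c2cc(-c3ccoc3)cc(-c3ccccc3O)n2)c1`, 29.5%
compound 3 `Oc1ccccc1-c1cc(-c2ccccn2)cc(-c2ccccc2O)n1`, 0.8%

Compound 3 stands lowest of the three; its gap to compound 1 is within the scatter, while compound 2 sits clearly higher. Compound 4 `Oc1cccc(-c2cc(-c3ccccn3)cc(-c3ccccc3O)n2)c1` differs from compound 3 by 3-hydroxyphenyl in place of 2-hydroxyphenyl on an aromatic carbon. Among the measured compounds shown here, no measured step bears directly on this change; the only step, a number 19.3 percentage points higher from compound 1 to compound 2 (beyond the scatter), concerns a different position. Compound 1, which already carries a 3-hydroxyphenyl group, gives 10.2%, a value close to that of compound 3. A step of no size beyond the scatter is therefore expected, a number 6.2 percentage points higher from compound 3 to compound 4 (within the scatter). Compound 4 is estimated at 7%, within 0% to 22%.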

Compound 4, a percentage reported as inhibition, at one concentration (the size of the read-out at that concentration, not a potency): 35.4%
Beside the measured number, compound 4's estimate is 28.4 percentage points below it; measured number outside the range, above it.
By their numbers in this assay, from the lowest: compounds 3 and 1 (each within the scatter of the next); then compounds 2 and 4 (each within the scatter of the next).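

Moving the hydroxyl group, so that 3-hydroxyphenyl replaces 2-hydroxyphenyl with the same atoms joined differently, gives a number 34.6 percentage points higher from compound 3 to compound 4 (beyond the scatter), so the hydroxyl's place on this ring matters greatly. With pyridin-2-yl on the other side, replacing thiophen-3-yl gives a number 25.2 percentage points higher from compound 1 to compound 4 (beyond the scatter), while replacing furan-3-yl gives only a number 5.9 percentage points higher from compound 2 to compound 4 (within the scatter). Nothing measured here explains the effect of moving the hydroxyl group. Still open, going by these compounds, is whether a 3-aminophenyl or 3-methoxyphenyl group would match 3-hydroxyphenyl here, and whether 2-hydroxyphenyl at the other ring position would behave the same way.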